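Swapping the benzyl group on a cinnamate anilide

A few compounds are considered here, and "the series" means these few. Any claim that something is new, unique, unknown or untested is made for them only; others in the source may bear on it.

Among the measured compounds shown here, compound 2 `COc1cc(/C=C/C(=O)OCC(=O)Nc2ccc(Cl)cc2)cc(OC)c1OCc1ccc(Cl)c(Cl)c1` is the one compound with a measured number in a functional assay on HL-60 cells (Homo sapiens) for cytotoxicity, read by MTT assay, with a stated time of 72 h (a lower number here means a stronger inhibitor, a higher number a weaker inhibitor), where compound 2 gives 73900 nM. Compound 1 `CCOc1ccc(COc2c(OC)cc(/C=C/C(=O)OCC(=O)Nc3ccccc3)cc2OC)cc1` reaches only a limit of this assay, reported as > 200000 nM. Compound 3 `CCOc1ccc(COc2c(OC)cc(/C=C/C(=O)OCC(=O)Nc3ccc(Cl)cc3)cc2OC)cc1` is not yet measured and differs from compound 2 by 4-ethoxyphenyl in place of 3,4-dichlorophenyl on a saturated chain carbon bound to an oxygen on an aromatic ring. A loss of potency beyond the usual scatter is expected, a 2.2-fold higher number from compound 2 to compound 3 (0.34 log units; beyond the scatter), because compound 1 with the same 4-ethoxybenzyl group sits at the limit of > 200000 nM in this assay, at which 1 of the 2 values shown sits. Compound 3 is estimated at 160000 nM, within 60000 nM to 400000 nM, and may itself return only a limit.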

Compound 3, half-maximal inhibitory concentration: > 200000 nM
Compound 3 ended at the assay's limit; the forecaster's own chance of this, stated with the estimate: 55%; middle value at least 1.2-fold (0.09 log units) away from the limit.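

In this assay, 4-ethoxyphenyl in place of 3,4-dichlorophenyl gives an at least 2.7-fold higher number from compound 2 to compound 3 (0.43 log units; beyond the scatter). Among the compounds shown here, this is the first comparison that changes the benzyl group alone, so it shows that this position alters the read-out, which compound 1 and compound 2, differing in two places, could not show. The step from hydrogen to chloro cannot be read, since compound 1 and compound 3 both stop at a limit: the limit of > 200000 nM in this assay, at which 2 of the 3 values shown sit.

From the compounds shown here alone, how a plain benzyl or a 4-chlorobenzyl group would behave here stays open. So does how an amine on the benzyl group would change the number.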